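From Ethynyl to Methoxycarbonyl on the Side Chain

The source may hold more compounds than are shown below. What is called first, only, known or untested is meant among the compounds shown, and "the series" means these compounds.

Of the compounds shown here, three sharing one core have been tested in an ADME assay on CEM-SS cells (Homo sapiens) for cytotoxicity, read by XTT assay, with a stated time of 6 days; on this read-out higher numbers stand for lower toxicity in this test and lower numbers for higher toxicity in this test. Compound 1 (`CCCC(=O)OCSc1ccccc1C(=O)NCCCC(N)=O`) gives 56.6 uM, compound 2 (`CCCC(=O)OCSc1ccccc1C(=O)NCCCNC(C)=O`) gives 21.1 uM, and compound 3 (`C#CCNC(=O)CNC(=O)c1ccccc1SCOC(=O)CCC`) gives 95.4 uM. The standing of compound 3 rests on two steps: a 1.7-fold higher number from compound 1 to compound 3 (0.23 log units; within the scatter), and a 4.5-fold higher number from compound 2 to compound 3 (0.66 log units; beyond the scatter). It therefore cannot be told apart from one neighbour but stands clear of the other.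

Compound 4 (`CCCC(=O)OCSc1ccccc1C(=O)NCC(=O)NCC(=O)OC`) has not yet been measured. It carries methoxycarbonyl in place of ethynyl on a saturated chain carbon bound to an amide-type nitrogen. Within the data shown here, no measured step makes this exact exchange, and no tested compound carries this ester. The closest evidence is the set of side-chain changes already described, together with a 2.7-fold lower number from compound 1 to compound 2 (0.43 log units; beyond the scatter). These changes stayed modest or smaller, so a large move in this assay is not expected. A slight drift downward is expected, in the direction of compound 2 at 21.1 uM, but not one beyond the scatter. The estimate is a 1.5-fold lower number from compound 3 to compound 4 (0.17 log units; within the scatter). For compound 4 the expected value is 65 uM, with an expected range of 25 uM to 140 uM.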

Compound 4, half-maximal toxic concentration: > 100 uM
Compound 4 gave a limit, no number; the forecaster's own chance of this, stated with the estimate: 10%; middle value at least 1.5-fold (0.18 log units) away from the limit.
By their numbers in this assay, from the lowest: compound 2; then compounds 1 and 3 (each within the scatter of the next). At a limit, above all of these: compound 4.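

In this assay, the read-out of compound 4 is a limit of the assay and not a number: the limit of > 100 uM in this assay, at which 1 of the 4 values shown sits. With methoxycarbonyl in place of ethynyl on a saturated chain carbon bound to an amide-type nitrogen, the step reads an at least 1.0-fold higher number from compound 3 to compound 4 (0.02 log units; that floor lies within the scatter), so this exchange shows no sign of a lower number, although its floor does not separate the two compounds. Compound 4 also stands clear of the 2-acetamidoethyl side chain, with an at least 4.7-fold higher number from compound 2 to compound 4 (0.67 log units; beyond the scatter), while an at least 1.7-fold higher number from compound 1 to compound 4 (0.24 log units; that floor lies within the scatter) leaves it unresolved from the 2-carbamoylethyl side chain, so the ((methoxycarbonyl)methyl)carbamoyl side chain now joins propargylcarbamoyl in standing clear of compound 2.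

From the compounds shown here alone, how far compound 4 lies past its limit remains open, and with it the order of compound 3 and compound 4. Also open, going by these compounds, is what a carboxylic acid or an amine at this place on the chain would give in this assay, and whether a longer chain carrying the methoxycarbonyl group would stay at the limit.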